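Swapping the Anilide for a Chlorophenyl Ether in the Chain

The source may hold more compounds than are shown below. What is called first, only, known or untested is meant among the compounds shown, and "the series" means these compounds.

Compound 1, `O=C(CNC(=O)c1cc(C(F)(F)F)cc(C(F)(F)F)c1)Nc1ccc(Cl)cc1`, gives 30% in a functional assay on PC-3 cells (Homo sapiens) for inhibition, read by WST assay, tested at 100 uM; a lower number here means a weaker effect, a higher number a stronger effect of the compound at the concentration tested.
Compound 2, `O=C(CCCNC(=O)c1cc(C(F)(F)F)cc(C(F)(F)F)c1)Nc1ccc(Cl)cc1`, gives 12% in this assay.
Compound 3, `O=C(Nc1ccc(Cl)cc1)C1CCN(C(=O)c2cc(C(F)(F)F)cc(C(F)(F)F)c2)CC1`, gives 39% in this assay.

Compound 2 stands lowest of the three numbers in this assay. Its nearest neighbour is compound 1, whose number lies above it by more than the usual scatter, and compound 3 lies further above still, again beyond the scatter. Among the measured compounds shown here, no two measured compounds differ in only one place, so no single step among them can be read directly.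

Compound 4, `O=C(NCCCOc1ccc(Cl)cc1)c1cc(C(F)(F)F)cc(C(F)(F)F)c1`, has not yet been measured. It differs from compound 2 in one place: 4-chlorophenoxy in place of (4-chlorophenyl)carbamoyl on a saturated chain carbon, three bonds along the chain from an amide-type nitrogen. For the measured compounds named here, nothing among the measured compounds shows how this exchange plays out, so the expectation for the step in this assay from compound 2 rests on the numbers alone. The account expects no step beyond the scatter in either direction, no change at the digits printed from compound 2 to compound 4 (within the scatter), because compound 2 already stands at 12% and leaves little room downward. Compound 4 is therefore estimated at 12% in this assay, within a range from 2% to 28%.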

Compound 4, a percentage reported as inhibition, at one concentration (the size of the read-out at that concentration, not a potency): 38%
Compound 4: the middle estimate sits 26 percentage points below what was measured; the whole stated range lies below it.
By their numbers in this assay, from the lowest: compound 2; then compounds 1, 4 and 3 (each within the scatter of the next).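

In this assay, among the compounds shown here, the exchange of (4-chlorophenyl)carbamoyl for 4-chlorophenoxy on a saturated chain carbon, three bonds along the chain from an amide-type nitrogen, gives a number 26 percentage points higher from compound 2 to compound 4 (beyond the scatter), the first step in this set that can be read at a single place. It shows that the low number of compound 2 is not set by the shared core and the chain alone: the group at the end of the chain can move the read-out beyond the scatter, although this remains the size of an effect at one concentration and not a potency. The exchange alters several things at once, with the entering group having fewer heavy atoms and no hydrogen-bond donor, and nothing available here separates these differences or explains the step.

On these data alone, it remains open whether an amine or a sulfur atom in place of the ether oxygen would give a number like that of compound 4. Also open, as far as these compounds go, is whether the same exchange would give a step of similar size on a shorter or longer chain, or with a different substituent in place of the chlorine.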